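The source may report more compounds than this note shows. Statements on the series, on what has been measured and on what is new or still open speak of the compounds shown alone.

Within the data shown here, compound 2 `CCNC(=O)c1cc(Oc2ccc(NC(=O)c3cc4cccnc4n(-c4ccccc4F)c3=O)cc2)ccn1` in a functional assay on NCI-H460 cells (Homo sapiens) for antiproliferative activity, read by MTT assay, with a stated time of 72 h (on this read-out higher numbers stand for weaker inhibition and lower numbers for stronger inhibition), gives 1230 nM, the highest of the two numbers so far; compound 1 `CNC(=O)c1cc(Oc2ccc(NC(=O)c3cc4cccnc4n(-c4ccccc4F)c3=O)cc2)ccn1` gives 590 nM, and the only measured step, a 2.1-fold higher number from compound 1 to compound 2 (0.32 log units; beyond the scatter), concerns a saturated chain carbon bound to an amide-type nitrogen. Among the measured compounds shown here, compound 3 `CCNC(=O)c1cc(Oc2ccc(NC(=O)c3cc4cccnc4n(-c4ccc(OC)cc4)c3=O)cc2)ccn1` differs from compound 2 by 4-methoxyphenyl in place of 2-fluorophenyl on an aromatic nitrogen, a change on an aromatic nitrogen that no measured step touches. With nothing to guide the direction, compound 3 is expected to stay close, with a 1.0-fold lower number from compound 2 to compound 3 (0.01 log units; within the scatter) and a wide range. The estimate for compound 3 is therefore 1200 nM, between 350 nM and 4500 nM.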

Compound 3, half-maximal inhibitory concentration: 1720 nM
Compound 3: the middle estimate sits 1.4-fold (0.16 log units) below what was measured; measured number inside the range.
By their numbers in this assay, from the lowest: compound 1; then compounds 2 and 3 (each within the scatter of the next).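

Exchanging 2-fluorophenyl for 4-methoxyphenyl on the aromatic nitrogen gives a 1.4-fold higher number from compound 2 to compound 3 (0.15 log units; within the scatter) and so leaves the read-out within the scatter. For this pair, the larger group with its hydrogen-bond acceptor therefore makes no clear difference at this position. Nothing measured here bears on the reason for this result.

On these data alone, whether the exchange would read the same on the methylamide of compound 1 remains open. So does how this position responds to a longer alkyl chain, or to a phenyl carrying an amine or a carboxylic acid.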